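The source may report more compounds than this note shows. Statements on the series, on what has been measured and on what is new or still open speak of the compounds shown alone.

In an ADME assay on MCF-10A cells (Homo sapiens) for cytotoxicity, read by MTT assay, with a stated time of 48 h (a higher number here means a weaker inhibitor, a lower number a stronger inhibitor), two compounds built on one shared core have been measured. Compound 1 `COc1cc2cc(C(=O)NCc3ccc(F)cc3)c(=O)oc2cc1OCCCOc1no[n+]([O-])c1S(=O)(=O)c1ccccc1` gives 8460 nM. Compound 2 `COc1cc2cc(C(=O)Nc3ccccc3)c(=O)oc2cc1OCCCOc1no[n+]([O-])c1S(=O)(=O)c1ccccc1` gives 9670 nM. Going by the values given here, the step of a 1.1-fold higher number from compound 1 to compound 2 (0.06 log units; within the scatter) lies within the scatter, so compound 2 stands level with compound 1, the only other measured compound, and neither can be called the stronger. Compound 3 `COc1cc2cc(C(=O)NCc3ccccc3)c(=O)oc2cc1OCCCOc1no[n+]([O-])c1S(=O)(=O)c1ccccc1` is not yet measured and differs from compound 2 by benzyl in place of phenyl on an amide-type nitrogen. Among the compounds with values here, the single measured step that bears on this change, a 1.1-fold higher number from compound 1 to compound 2 (0.06 log units; within the scatter), also swapped one group on that same amide nitrogen for another and produced nothing beyond the scatter. On that basis the step of a 1.1-fold lower number from compound 2 to compound 3 (0.03 log units; within the scatter) is expected to stay within the scatter as well. For compound 3 the estimated value in this assay is 9000 nM, with a range from 4500 nM to 18000 nM.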

Compound 3, half-maximal inhibitory concentration: 7030 nM
Beside the measured number, compound 3's estimate is 1.3-fold (0.11 log units) above it; measured number inside the range.
By their numbers in this assay, from the lowest: compounds 3, 1 and 2 (each within the scatter of the next).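

In this assay, benzyl in place of phenyl on the amide-type nitrogen gives a 1.4-fold lower number from compound 2 to compound 3 (0.14 log units; within the scatter), so a group with one more carbon at this position leaves the reading level. Hydrogen in place of fluoro on an aromatic carbon gives a 1.2-fold lower number from compound 1 to compound 3 (0.08 log units; within the scatter), which adds a first look at a change on the ring itself, and this too does not separate the two compounds. No measurement at hand offers an explanation for these readings.

The compounds shown leave open whether a longer chain such as phenethyl, or a group carrying an amine, on the same nitrogen would move the number beyond the scatter. They also leave open whether chloro or methoxy on that aromatic carbon would do so.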